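The source may report more compounds than this note shows. Statements on the series, on what has been measured and on what is new or still open speak of the compounds shown alone.

Compound 1 `O=C(Nc1ccccc1)c1c(O)c2cccnc2n(-c2ccccc2)c1=O`: 4.6%
Compound 2 `O=C(Nc1cccc(Cl)c1)c1c(O)c2cccnc2n(-c2ccccc2)c1=O`: 7.6%

Within the data shown here, in a functional assay on the whole organism for inhibition, with Rattus norvegicus as the target, read by paw edema, at a dose of 100 mg/kg by the oral route (a lower number here means less inhibition, a higher number more inhibition at the dose given (going by the name of the read-out)), compound 2 gives 7.6%, and the only measured step, a number 3 percentage points higher from compound 1 to compound 2 (within the scatter), leaves the two values within the scatter of each other. Compound 3 `O=C(Nc1cccnc1)c1c(O)c2cccnc2n(-c2ccccc2)c1=O` differs from compound 2 by pyridin-3-yl in place of 3-chlorophenyl on an amide-type nitrogen. Among the measured compounds shown here, no measured step bears on this kind of change; the single measured step concerns a chloro in place of hydrogen and is small. Both measured numbers are low. For compound 3 the step expected is a number 1.6 percentage points lower from compound 2 to compound 3 (within the scatter), nothing beyond the scatter. Compound 3 is therefore estimated at 6%, with a range from 0% to 16%.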

Compound 3, a percentage reported as inhibition, in the whole organism at one dose (the size of the read-out at that dose, not a potency): 30.3%
Beside the measured number, compound 3's estimate is 24.3 percentage points below it, outside the stated range (above it).
By their numbers in this assay, from the lowest: compounds 1 and 2 (each within the scatter of the next); then compound 3.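

In this assay, pyridin-3-yl on the amide-type nitrogen gives a number 22.7 percentage points higher from compound 2 to compound 3 (beyond the scatter), and against the unsubstituted phenyl it gives a number 25.7 percentage points higher from compound 1 to compound 3 (beyond the scatter). Unlike the chloro step, which stayed within the scatter, this exchange of the ring itself moves the number beyond the scatter, with a ring nitrogen and a hydrogen-bond acceptor entering. Nothing measured here explains the rise. Going by these compounds, whether pyridin-2-yl or pyridin-4-yl on this nitrogen would do the same stays open. So does whether a chloro or an amine on the pyridin-3-yl ring would keep the gain.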